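The source may hold more compounds than are shown below. What is called first, only, known or untested is meant among the compounds shown, and "the series" means these compounds.

The measured compounds so far:

- compound 1, `CCNC(=O)CCc1cccc2c1B(O)OC2`, in a functional assay on HCT-116 cells (Homo sapiens) for antiproliferative activity, read by MTT assay, with a stated time of 72 h (on this read-out higher numbers stand for weaker inhibition and lower numbers for stronger inhibition), gives > 100000 nM
- compound 2, `CC(C)(C)OC(=O)NCc1ccc(NC(=O)CCc2cccc3c2B(O)OC3)cc1`, in the same assay gives 2300 nM

The figure for compound 1 is a limit of the assay and not a number; compound 1 sits at the limit of > 100000 nM in this assay, at which 1 of the 2 values shown sits. Compound 2 does give a number, so the two values can only be said to lie apart.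

Compound 3, `O=C(CCc1cccc2c1B(O)OC2)Nc1cccc(I)c1`, has not yet been tested. It differs from compound 1 in one place: 3-iodophenyl in place of ethyl on an amide-type nitrogen. Since compound 1 shows only a limit, the step to compound 3 cannot be read from measured pairs. Compound 3 is nevertheless expected to give a number rather than a limit, landing nearer to compound 2 with its 2300 nM. The expected step is an at least 33-fold lower number from compound 1 to compound 3 (1.52 log units; beyond the scatter), well beyond the scatter and toward stronger inhibition. Compound 3 is therefore estimated at 3000 nM, with a likely range from 700 nM to 15000 nM.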

Compound 3, half-maximal inhibitory concentration: 2300 nM
Beside the measured number, compound 3's estimate is 1.3-fold (0.12 log units) above it; the measured number falls inside the stated range.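

Putting 3-iodophenyl in place of ethyl on the amide-type nitrogen gives an at least 43-fold lower number from compound 1 to compound 3 (1.63 log units; beyond the scatter) in this assay, a large move toward stronger inhibition. Compound 1 shows a limit and not a number, so this step gives only the smallest possible size of the change: the limit of > 100000 nM in this assay, at which 1 of the 3 values shown sits.

Compound 2 gives 2300 nM and compound 3 gives 2300 nM, so the much larger substituent of compound 2 is not needed to reach a number of this size on the shared core.

From the compounds shown here alone, whether the step comes from the aromatic ring or from the iodine stays open, and a plain phenyl on this nitrogen would help to separate the two. The compounds shown also leave open how a longer alkyl chain in place of ethyl would behave.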